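The compounds below may be only part of what the source reports. "The series", "measured", "known", "first", "only" and "open" are said of these compounds alone.

Measured compounds and their values:
compound 1, `Cc1ccccc1-c1c(C(=O)N(C)Cc2ccccc2Cl)n(C)c(=O)c2ccccc12`, 19 nM
compound 2, `CCN(Cc1ccccc1OC)C(=O)c1c(-c2ccccc2C)c2ccccc2c(=O)n1C`, 34 nM
compound 3, `Cc1cc2c(-c3ccccc3)c(NC(=O)N(C)Cc3ccccc3)n(C)c(=O)c2cc1C`, 16 nM

All three were tested in an assay on IM-9 cells for binding affinity to Substance-P receptor (Homo sapiens); a lower number here means a stronger inhibitor, a higher number a weaker inhibitor. Compound 1 stands second highest of the three numbers, yet its nearest neighbour, compound 3, and its furthest, compound 2, both lie within the usual scatter of it, so these three compounds cannot be placed in an order on these results alone; they read as roughly equal binders.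

The next compound, compound 4, `Cc1cc(C)cc(CN(C)C(=O)c2c(-c3ccccc3C)c3ccccc3c(=O)n2C)c1`, has not yet been measured in this assay. Compared with compound 1, the change is 3,5-dimethylphenyl in place of 2-chlorophenyl on a saturated chain carbon bound to an amide-type nitrogen. Both groups are plain aromatic rings carrying no hydrogen-bond donors or acceptors and no charge, so the swap mainly trades a chlorine for two methyl carbons and moves the substitution around the ring. Among the measured compounds, no pair differs at exactly this place, and the only other variation on this benzyl group, the methoxy-bearing ring of compound 2, went together with a different group on the amide nitrogen, so no clean precedent exists.

In the absence of such a precedent, the step from compound 1 to compound 4 is expected to be small, a 2.1-fold higher number from compound 1 to compound 4 (0.32 log units; beyond the scatter), most likely a slight weakening that may not exceed the scatter. Compound 4 is therefore estimated at 40 nM, with a range from 10 nM to 160 nM.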

Compound 4, half-maximal inhibitory concentration: 32 nM
Compound 4: middle estimate off by 1.3-fold (0.10 log units), on the high side, within the range that was stated.
By their numbers in this assay, from the lowest: compounds 3, 1, 4 and 2 (each within the scatter of the next, the first and the last beyond it).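

Among these compounds, replacing 2-chlorophenyl with 3,5-dimethylphenyl, on a saturated chain carbon bound to an amide-type nitrogen, gives a 1.7-fold higher number from compound 1 to compound 4 (0.23 log units; within the scatter) in this assay; this is the first reading in which only this one place differs. The two rings carry different groups, chlorine on one and two methyl groups on the other, at different ring positions, yet the two compounds cannot be told apart in this assay. At this place, then, the 2-chlorobenzyl and 3,5-dimethylbenzyl forms both remain in the same range of binding, and no measurement is available that could explain why.

Both rings are all-carbon aromatic rings without charge, so the compounds shown leave open how this place would respond to a pyridine ring, or to a hydroxyl group, an amine or a carboxylic acid on the ring. They also leave open whether the type of ring substituent or its position matters more, a question that 3,5-dichlorophenyl could help separate by joining the chlorine of compound 1 to the substitution positions of compound 4.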